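This account rests on a few compounds, and the source may have more. Where it says the series, first, only, none or still open, it means among the compounds named here.

Of the compounds shown here, three have been measured in a functional assay on A549 cells (Homo sapiens) for inhibition, read by MTT assay, with a stated time of 72 h; on this read-out higher numbers stand for weaker inhibition and lower numbers for stronger inhibition. Compound 1 `CNc1nc(C)c(C(=O)N/N=C/c2ccccc2C(F)(F)F)s1` gives only a limit there, > 100 ug/mL. Compound 2 `CNc1nc(C)c(C(=O)N/N=C/c2cccc(C(F)(F)F)c2)s1` also gives only a limit, > 100 ug/mL, so compound 2 stands at the limit of > 100 ug/mL in this assay, at which 2 of the 3 values shown sit. Compound 3 `CN(C(=O)NC(=O)c1cccc(C(F)(F)F)c1)c1nc(C(F)(F)F)c(C(=O)N/N=C/c2ccccc2C(F)(F)F)s1`, by contrast, gives a number, 12.1 ug/mL. The step from compound 2 to compound 4 `CNc1nc(C)c(C(=O)N/N=C/c2cc(C(F)(F)F)cc(C(F)(F)F)c2)s1` is trifluoromethyl in place of hydrogen on an aromatic carbon, a trifluoromethyl in place of hydrogen on an aromatic carbon, meta to a trifluoromethyl group. Among the measured compounds shown here, no measured pair differs in one place, so nothing measured shows how such a change acts. The expected step from compound 2 to compound 4 is therefore none beyond the scatter, a step that the limit leaves unreadable from compound 2 to compound 4. Compound 4 is estimated at 150 ug/mL, within 40 ug/mL to 500 ug/mL.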

Compound 4, half-maximal inhibitory concentration: > 100 ug/mL
Compound 4 was reported as a limit; the forecaster's own chance of this, stated with the estimate: 70%; the middle value lies beyond the limit too.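

Compound 2 and compound 4 are both reported only as limits, so no step can be read between them: the limit of > 100 ug/mL in this assay, at which 3 of the 4 values shown sit.

On these data alone, whether the added trifluoromethyl group changes inhibition of these cells at all remains open.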